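The compounds below may be only part of what the source reports. "The series", "measured", "known", "first", "only" and "open" are said of these compounds alone.

Compounds measured in a functional assay on KYSE-450 cells (Homo sapiens) for inhibition, read by MTT assay, with a stated time of 48 h; on this read-out higher numbers stand for weaker inhibition and lower numbers for stronger inhibition:

Compound 1, `COc1cc(NCc2ccc(Cl)cc2)cc(OC)c1OC`: > 80000 nM
Compound 2, `C/C=C/C=C/C(=O)N(Cc1ccc(OC)c(O)c1)c1cc(OC)c(OC)c(OC)c1`: 180 nM

Going by the values given here, of these two, compound 2 carries the only number; it is therefore the reference point, since the other value is not a number at all. For compound 1 this assay reports a limit, > 80000 nM, and nothing more precise than that; the same holds for (the limit of > 80000 nM in this assay, at which 1 of the 2 values shown sits). Among the compounds with values here, no step between two measured compounds is available. Compound 1 and compound 2 differ in more than one place.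

Compound 3, `C=CC(=O)N(Cc1ccc(OC)c(O)c1)c1cc(OC)c(OC)c(OC)c1`, has not yet been measured in this assay. It is reached from compound 2 by a single change: vinyl in place of penta-1,3-dien-1-yl on a carbonyl carbon. The amide nitrogen with its two aromatic substituents is kept, and only the chain on the carbonyl carbon is shortened from the penta-1,3-dien-1-yl group to a vinyl group.

With nothing measured on the penta-1,3-dien-1-yl to vinyl exchange itself, the expectation is for a step that stays within the usual scatter, a 1.4-fold higher number from compound 2 to compound 3 (0.14 log units; within the scatter), with no firm direction. Compound 3 is accordingly estimated at 250 nM, within a range from 60 nM to 1000 nM.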

Compound 3, half-maximal inhibitory concentration: 160 nM
The estimate for compound 3 lay 1.6-fold (0.19 log units) above the measured number; measured number inside the range.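

In this assay, going by these compounds alone, the chain on the carbonyl carbon can now be read for the first time, and vinyl in place of penta-1,3-dien-1-yl gives a 1.1-fold lower number from compound 2 to compound 3 (0.05 log units; within the scatter) and so leaves compound 2 and compound 3 level with each other. At this place, then, the full penta-1,3-dien-1-yl group, with its second double bond outside the aromatic rings, is not needed for a value of this size, and the shorter vinyl group serves as well within this one comparison. Nothing known here accounts for this result or says what the chain contributes.

Still open, as far as these compounds go, is whether the carbonyl carbon would keep such a value with a chain lacking any double bond, such as ethyl or a longer saturated alkyl chain, or with a phenyl ring in the same place. Compound 1 gives > 80000 nM as a limit of the assay and not a number, and because it differs from compound 2 in more than one place, it cannot show which part of the structure matters.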